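This account rests on a few compounds, and the source may have more. Where it says the series, first, only, none or still open, it means among the compounds named here.

Compound 1 `CC(C)Cc1ccc(C(C)c2nnc3n2N=C(c2ccc(OC(F)(F)F)cc2)CS3)cc1` carries the highest number of the three compounds measured in a functional assay on HepG2 cells (Homo sapiens) for inhibition, read by sulforhodamine B assay, with a stated time of 72 h (on this read-out lower numbers stand for stronger inhibition and higher numbers for weaker inhibition), where compound 1 gives 9700 nM. Compound 2 `COc1ccc(C2=Nn3c(nnc3C(C)c3ccc(-c4ccccc4)c(F)c3)SC2)cc1` gives 4200 nM in this assay, and compound 3 `CC(c1ccc(-c2ccccc2)c(F)c1)c1nnc2n1N=C(c1ccc(F)cc1)CS2` gives 5100 nM. Compound 4 `COc1ccc(C2=Nn3c(nnc3C(C)c3ccc(CC(C)C)cc3)SC2)cc1` differs from compound 1 by methyl in place of trifluoromethyl on an oxygen on an aromatic ring. Going by the values given here, no measured step repeats this exact change; the only single-place step available, a 1.2-fold higher number from compound 2 to compound 3 (0.08 log units; within the scatter), exchanges one group on an aromatic carbon and stays within the scatter, so nothing here points to a large move. Compound 4 is therefore expected to land near compound 1, with a 1.2-fold lower number from compound 1 to compound 4 (0.08 log units; within the scatter) in this assay. The estimate for compound 4 is 8000 nM, expected to fall between 3000 nM and 22000 nM.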

Compound 4, half-maximal inhibitory concentration: 3800 nM
Beside the measured number, compound 4's estimate is 2.1-fold (0.32 log units) above it; the measured number falls inside the stated range.
By their numbers in this assay, from the lowest: compounds 4, 2, 3 and 1 (each within the scatter of the next, the first and the last beyond it).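

In this assay, going by these compounds alone, the change from trifluoromethoxy to methoxy gives a 2.6-fold lower number from compound 1 to compound 4 (0.41 log units; beyond the scatter) and is the first step here to lie beyond the scatter, though only modestly. The only earlier step, a 1.2-fold higher number from compound 2 to compound 3 (0.08 log units; within the scatter), stayed within the scatter, so this oxygen on an aromatic ring is the first place shown where a single change moves the number beyond it. Nothing available explains this step. The compounds shown leave open how an ethyl group or a longer chain on this oxygen would read, or an amine in its place. They also leave open whether the same change gives a similar step on the core of compound 2.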